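Aryl variation on the cinnamamide chain of the shared core

The source may report more compounds than this note shows. Statements on the series, on what has been measured and on what is new or still open speak of the compounds shown alone.

Compound 1 `COc1cc(/C=C/C(=O)Nc2cc3c(Nc4ccc(F)c(Cl)c4)ncnc3cc2O[C@H]2CCOC2)cc(OC)c1`, compound 2 `O=C(/C=C/c1cc(Br)c(O)c(Br)c1)Nc1cc2c(Nc3ccc(F)c(Cl)c3)ncnc2cc1O[C@H]1CCOC1` and compound 3 `O=C(/C=C/c1ccccc1[N+](=O)[O-])Nc1cc2c(Nc3ccc(F)c(Cl)c3)ncnc2cc1O[C@H]1CCOC1` share one core and differ only in the aryl group on the double-bonded chain carbon. In a functional assay on PC-3 cells (Homo sapiens) for cytotoxicity, read by MTT assay, with a stated time of 72 h (a lower number here means a stronger inhibitor, a higher number a weaker inhibitor), compound 1 gives 25600 nM and compound 2 gives 25500 nM; the step of a 1.0-fold lower number from compound 1 to compound 2 (0.00 log units; within the scatter) is within the scatter. Compound 3 gives 7760 nM and stands lowest of the three numbers, with a 3.3-fold lower number from compound 1 to compound 3 (0.52 log units; beyond the scatter) and a 3.3-fold lower number from compound 2 to compound 3 (0.52 log units; beyond the scatter) both beyond the scatter.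

Compound 4 `COc1ccc(/C=C/C(=O)Nc2cc3c(Nc4ccc(F)c(Cl)c4)ncnc3cc2O[C@H]2CCOC2)cc1` is the next variation: 4-methoxyphenyl in place of 2-nitrophenyl on a double-bonded chain carbon bound to a double-bonded chain carbon. The two steps that bear on it, a 3.3-fold lower number from compound 1 to compound 3 (0.52 log units; beyond the scatter) and a 3.3-fold lower number from compound 2 to compound 3 (0.52 log units; beyond the scatter), both run toward the 2-nitrophenyl and each is modest. Compound 4 moves away from the 2-nitrophenyl toward an aryl carrying a single methoxy group, as the 3,5-dimethoxyphenyl of compound 1 carries methoxy groups only. For compound 4 a modest rise back is therefore expected, about a 1.9-fold higher number from compound 3 to compound 4 (0.29 log units; within the scatter). The expected value for compound 4 is 15000 nM, with a range from 6000 nM to 40000 nM.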

Compound 4, half-maximal inhibitory concentration: 2240 nM
Compound 4: middle estimate off by 6.7-fold (0.83 log units), on the high side; the whole stated range lies above it.
By their numbers in this assay, from the lowest: compound 4; then compound 3; then compounds 2 and 1 (each within the scatter of the next).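

Methoxy substitution alone does not fix the number at this position in this assay: 4-methoxyphenyl and 3,5-dimethoxyphenyl sit far apart (an 11-fold lower number from compound 1 to compound 4 (1.06 log units; beyond the scatter)). The 4-methoxyphenyl also reads lower than the 2-nitrophenyl (a 3.5-fold lower number from compound 3 to compound 4 (0.54 log units; beyond the scatter)) and the 3,5-dibromo-4-hydroxyphenyl (an 11-fold lower number from compound 2 to compound 4 (1.06 log units; beyond the scatter)), so the aryl on the double-bonded chain carbon spans a wider range than the first three compounds showed, and the lowest number in the set does not need a nitro group. Nothing at hand accounts for these steps.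

Open, going by these compounds, is whether the methoxy group itself matters, or whether other groups on the aryl would read the same. An unsubstituted phenyl would give the baseline for that comparison, and an amine or a carboxylic acid in place of the methoxy would test how far the low number extends.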